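Cytotoxicity limits and an anilino swap

The compounds below may be only part of what the source reports. "The series", "measured", "known", "first", "only" and "open" are said of these compounds alone.

Compound 1 `C#CCNCc1ccc2c(Br)cc(Br)c(O)c2n1`: > 25000 nM, a limit
Compound 2 `COCCOCc1ccc2c(Br)cc(Br)c(O)c2n1`: > 100000 nM, a limit

Both values come from an ADME assay on HeLa cells (Homo sapiens) for cytotoxicity, read by LDH release, with a stated time of 24 h (on this read-out higher numbers stand for weaker inhibition and lower numbers for stronger inhibition), so compound 2 stands only at a limit, with no exact number. Compound 3 `Oc1c(Br)cc(Br)c2ccc(CNc3ccccc3)nc12` carries anilino in place of 2-methoxyethoxy on a saturated chain carbon bound to an aromatic carbon. Among the measured compounds shown here, the only measured step, a step that the two limits leave unreadable from compound 1 to compound 2, has no readable size and gives weak guidance. For the measured compounds named here, the lower limit of compound 1, > 25000 nM, is the only hint that another group at this place may read lower. The expected change is an at least 2.5-fold lower number from compound 2 to compound 3 (0.39 log units; beyond the scatter), toward stronger inhibition in this assay, with its size uncertain. Compound 3 is estimated at 40000 nM, with an expected range of 10000 nM to 100000 nM.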

Compound 3, half-maximal inhibitory concentration: 100000 nM
Estimate against measurement, compound 3: 2.5-fold (0.40 log units) below; measured number inside the range.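

In this assay, compound 3 gives the only exact number shown so far, 100000 nM, so with anilino at this saturated chain carbon the read-out yields a value. Compound 2 remains a limit, > 100000 nM. Anilino in place of 2-methoxyethoxy gives a number no higher from compound 2 to compound 3 (the limit leaves the size open) on this read-out. Neither new step has a readable size, so the change from either earlier group to anilino cannot be measured.

Compound 1 is also only a limit, > 25000 nM. On these data alone, whether a simple methylamino group or a carboxylic acid at this place would give a clearly lower number stays open.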